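A few compounds are considered here, and "the series" means these few. Any claim that something is new, unique, unknown or untested is made for them only; others in the source may bear on it.

The measured compounds in a functional assay on LoVo cells (Homo sapiens) for inhibition, read by MTT assay, with a stated time of 48 h; a higher number here means a weaker inhibitor, a lower number a stronger inhibitor:
- compound 1 `COc1ccc(N(C)c2nc(C)nc3ccccc23)cc1C(=O)NCC[Se]C#N` gives 561 nM
- compound 2 `COc1ccc(N(C)c2nc(C)nc3ccccc23)cc1OCCCCC[Se]C#N` gives 5210 nM
- compound 3 `COc1ccc(N(C)c2nc(C)nc3ccccc23)cc1` gives 8 nM

Compound 3 stands lowest of the three numbers in this assay: its nearest neighbour is compound 1, with a 70-fold lower number from compound 1 to compound 3 (1.85 log units; beyond the scatter) separating them, and its furthest is compound 2, separated by a 650-fold lower number from compound 2 to compound 3 (2.81 log units; beyond the scatter). Compound 4 `COc1ccc(N(C)c2nc(C)nc3ccccc23)cc1C[Se]C#N` is the next compound on this path; it differs from compound 3 by a group of 4 heavy atoms (2 carbon, 1 nitrogen, 1 selenium; no ring) in place of a hydrogen atom, on an aromatic carbon.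

Among the compounds with values here, two measured steps bear on this change, since both compound 1 and compound 2 likewise carry a selenium-containing group on that same aromatic carbon where compound 3 carries only a hydrogen atom. Both of those steps were large: a 70-fold lower number from compound 1 to compound 3 (1.85 log units; beyond the scatter) and a 650-fold lower number from compound 2 to compound 3 (2.81 log units; beyond the scatter). The group entering in compound 4 is counted at 4 heavy atoms, fewer than the groups of 8 and 9 heavy atoms in compound 1 and compound 2, so compound 4 is expected to give a higher number than compound 3, with a step of a 31-fold higher number from compound 3 to compound 4 (1.49 log units; beyond the scatter) that is clearly beyond the scatter, though possibly less than the step to compound 1. Compound 4 is therefore estimated at 250 nM, within 60 nM to 1500 nM.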

Compound 4, half-maximal inhibitory concentration: 277 nM
The estimate for compound 4 lay 1.1-fold (0.04 log units) below the measured number; the range from low to high includes it.
By their numbers in this assay, from the lowest: compound 3; then compound 4; then compound 1; then compound 2.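

Compound 4 shows that even the smallest selenium-bearing group here, of 4 heavy atoms, on the aromatic carbon ortho to a methoxy group, costs most of what the larger groups cost in this assay, with a 35-fold higher number from compound 3 to compound 4 (1.54 log units; beyond the scatter). Shortening the group still brings a gain over the larger ones, modest against the amide-linked group with a 2.0-fold lower number from compound 1 to compound 4 (0.31 log units; beyond the scatter) and large against the ether-linked chain with a 19-fold lower number from compound 2 to compound 4 (1.27 log units; beyond the scatter), so across these three compounds the number rises with the count of heavy atoms in the group. No measurement is available that accounts for these steps.

Going by these compounds, whether the loss comes from the selenium and nitrile or from any group at this carbon stays open. A plain methyl group, a hydroxymethyl group or an amine here would separate the two.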